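This account rests on a few compounds, and the source may have more. Where it says the series, first, only, none or still open, it means among the compounds named here.

In a functional assay on HepG2 cells (Homo sapiens) for inhibition, read by MTT assay (a higher number here means a weaker inhibitor, a lower number a stronger inhibitor), compound 1 `COc1cc2ncnc(Nc3ccc(NC(=O)c4cccc(C)c4)cc3)c2cc1OC` gives 7500 nM. Compound 2 `COc1cc2ncnc(Nc3ccc(NC(=O)c4ccc(C(C)(C)C)cc4)cc3)c2cc1OC` shares its core and amide. Compound 2 reads > 100000 nM, which is a limit of the assay and not a number; (the limit of > 100000 nM in this assay, at which 1 of the 2 values shown sits). Within the data shown here, one measured step bears on what follows: an at least 13-fold higher number from compound 1 to compound 2 (1.12 log units; beyond the scatter), a large step that brought in the 4-(tert-butyl)phenyl group. Compound 3 `COc1cc2ncnc(Nc3ccc(NC(=O)c4ccccc4F)cc3)c2cc1OC` gives that group up again, with 2-fluorophenyl in place of 4-(tert-butyl)phenyl on a carbonyl carbon. The group that enters is not the 3-methylphenyl of compound 1, so the earlier step can only be a rough guide, but compound 1, at 7500 nM, remains the closest measured comparison. A large step toward a lower number is therefore expected in this assay, and the expected step is an at least 10-fold lower number from compound 2 to compound 3 (1.00 log units; beyond the scatter). For compound 3 the estimate is 10000 nM, with an expected range of 2500 nM to 50000 nM.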

Compound 3, half-maximal inhibitory concentration: 13000 nM
For compound 3 the middle estimate is 1.3-fold (0.11 log units) below the measured one, within the range that was stated.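

Replacing 4-(tert-butyl)phenyl with 2-fluorophenyl on the carbonyl carbon gives an at least 7.6-fold lower number from compound 2 to compound 3 (0.88 log units; beyond the scatter) in this assay, so the loss seen with 4-(tert-butyl)phenyl is not shared by every substituted phenyl group at this place. On these data alone, compound 2 stands at a limit of the assay and not a number, so the full size of that step stays unknown: the limit of > 100000 nM in this assay, at which 1 of the 3 values shown sits. The other comparison reads a 1.7-fold higher number from compound 1 to compound 3 (0.24 log units; within the scatter), so 3-methylphenyl and 2-fluorophenyl on this carbonyl carbon cannot be told apart in this assay.

As far as these compounds go, how an amine or a carboxylic acid on the phenyl ring would read remains open. So does whether any group at this place could bring the number clearly lower than the readings of compound 1 and compound 3.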